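A Single Stereocentre Flip on a Weakly Cytotoxic Scaffold

A few compounds are considered here, and "the series" means these few. Any claim that something is new, unique, unknown or untested is made for them only; others in the source may bear on it.

Two compounds from this study share a core and differ in the aromatic ether attached to it. Compound 1 `C=C1CC[C@@H]2[C@](C)(CO)[C@H](O)CC[C@@]2(C)[C@@H]1C/C=C1/C(=O)OC[C@H]1Oc1c(Cl)cc(Cl)c2cccnc12` was tested in an ADME assay on SNB-19 cells (Homo sapiens) for cytotoxicity, read by MTT assay, with a stated time of 24 h (on this read-out lower numbers stand for higher toxicity in this test and higher numbers for lower toxicity in this test), and gives 85200 nM, a weak effect. Compound 2 `C=C1CC[C@@H]2[C@](C)(CO)[C@H](O)CC[C@@]2(C)[C@@H]1C/C=C1/C(=O)OC[C@@H]1Oc1cccc2ccc(C)nc12` was also run in this assay and returns only a limit, > 100000 nM, so no exact number is known for it. That limit is the ceiling of this assay, where one of the two recorded values sits (the limit of > 100000 nM in this assay, at which 1 of the 2 values shown sits). Compound 3 `C=C1CC[C@@H]2[C@](C)(CO)[C@H](O)CC[C@@]2(C)[C@@H]1C/C=C1/C(=O)OC[C@H]1Oc1cccc2ccc(C)nc12` is the compound still to be measured. Compared with compound 2, (the two compounds have the same atoms and bonds and differ only in configuration as drawn: 1 of 7 stereo elements differ; a stereocentre at a saturated ring carbon is drawn R in compound 2 and S in compound 3). For the measured compounds named here, with no measured step of this kind to draw on, the step of an at least 1.0-fold lower number from compound 2 to compound 3 (0.02 log units; that floor lies within the scatter) is expected to stay within the usual scatter, in either direction. Compound 3 is therefore expected to give roughly 95000 nM in this assay, somewhere within 50000 nM to 200000 nM, with a fair chance that it too reaches only the limit.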

Compound 3, half-maximal cytotoxic concentration: > 100000 nM
Compound 3 gave a limit, no number; the forecaster's own chance of this, stated with the estimate: 60%; middle value at least 1.0-fold (0.02 log units) away from the limit.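

At this position the two drawn configurations cannot be told apart in this assay, because compound 2 and compound 3 both end at a limit and the step between them cannot be read: the limit of > 100000 nM in this assay, at which 2 of the 3 values shown sit.

Compound 3 does allow a new comparison between two compounds with the same drawn configuration, where 2-methylquinolin-8-yl replaces 5,7-dichloroquinolin-8-yl and gives an at least 1.1-fold higher number from compound 1 to compound 3 (0.06 log units; that floor lies within the scatter). Only a floor is known for this step, and its true size may be larger.

Going by these compounds, whether the flip would change a value that lies inside the measurable range stays open. Also open, on these data alone, is how the read-out would respond to a carboxylic acid or an amine on the aromatic part of the ether.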